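Carbamate replacement on the aryl oxygen of compound 2

The source may report more compounds than this note shows. Statements on the series, on what has been measured and on what is new or still open speak of the compounds shown alone.

Two compounds of this series have numbers in a functional assay on PANC-1 cells (Homo sapiens) for inhibition, read by MTT assay, with a stated time of 24 h, tested at 10 uM (on this read-out higher numbers stand for more inhibition at the one concentration tested (going by the name of the read-out) and lower numbers for less inhibition), so far. Compound 1 `CC(C)=CCC/C(C)=C/CC1Cc2c(OCCCNC(=O)c3ccc([N+](=O)[O-])cc3)cc(=O)n(CCCO)c2CC1(C)C` gives 6.5% in this assay. Compound 2 `CC(C)=CCC/C(C)=C/CC1Cc2c(OCCCOc3ccc(Cl)cc3)cc(=O)n(CCCO)c2CC1(C)C` gives 0% in this assay, the lowest of the two numbers, though the step of a number 6.5 percentage points lower from compound 1 to compound 2 (within the scatter) is within the scatter, so neither compound can be told apart from the other on these data. Both numbers sit close to no inhibition at the single concentration tested.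

Compound 3 `CC(C)=CCC/C(C)=C/CC1Cc2c(OC(=O)Nc3ccc(Cl)cc3)cc(=O)n(CCCO)c2CC1(C)C` is the next member awaiting a number. Its change from compound 2 is (4-chlorophenyl)carbamoyl in place of 3-(4-chlorophenoxy)propyl on an oxygen on an aromatic ring; the shortened link to the chlorophenyl ring is the whole of the change. The only step shown, the one from compound 1 to compound 2, altered the group at the far end of the same chain and moved the number very little, which gives no sign that the side group on this oxygen drives the read-out. A step of no more than the scatter, a number 5 percentage points higher from compound 2 to compound 3 (within the scatter), is therefore expected from compound 2 to compound 3. Compound 3 is estimated at 5% in this assay, between 0% and 20%.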

Compound 3, a percentage reported as inhibition, at one concentration (the size of the read-out at that concentration, not a potency): 4.3%
Estimate against measurement, compound 3: 0.7 percentage points above, within the range that was stated.
By their numbers in this assay, from the lowest: compounds 2, 3 and 1 (each within the scatter of the next).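

Among these compounds, this is the first step at the oxygen on an aromatic ring itself, not at the far end of the chain: the whole side group changes while the 4-chlorophenyl ring stays, and this assay gives a number 4.3 percentage points higher from compound 2 to compound 3 (within the scatter). The entering (4-chlorophenyl)carbamoyl brings a hydrogen-bond donor and a double bond outside aromatic rings, neither of which 3-(4-chlorophenoxy)propyl carries, yet on this read-out compound 2 and compound 3 cannot be told apart, so neither the propyl link nor the carbamoyl link can be preferred on these data. No measurement is available that bears on why this exchange stays within the scatter.

Still open, from the compounds shown here alone, is whether an amine or a carboxylic acid on this oxygen's side group, or a longer chain in place of the propyl, would give a number clearly away from those of compound 2 and compound 3. All the compounds shown share one core and the same 3-hydroxypropyl group, so whether a change at any other place would alter the read-out also remains open.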